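The compounds below may be only part of what the source reports. "The series", "measured", "known", "first", "only" and "open" are said of these compounds alone.

Compound 1 `CCCn1c(=O)n(CCOC)c(=O)c2[nH]cnc21` gives 2500 nM in an assay on Cerebral cortex for binding affinity to adenosine receptor A1 (Cavia porcellus), read by radioligand binding; a lower number here means a stronger inhibitor, a higher number a weaker inhibitor. Compound 2 `CCCn1c(=O)n(CCOCC)c(=O)c2[nH]cnc21` gives 1900 nM in this assay. Compound 3 `C=CCCn1cnc2c1c(=O)n(C)c(=O)n2CCC` gives 6000 nM in this assay.

Among these three, compound 3 carries the highest number, beyond the scatter from both compound 1 and compound 2. Compound 4 `CCCn1c(=O)n(C)c(=O)c2c1ncn2CCCO` differs from compound 3 by hydroxymethyl in place of vinyl on a saturated chain carbon, two bonds along the chain from an aromatic nitrogen. Going by the values given here, the only measured step, a 1.3-fold lower number from compound 1 to compound 2 (0.12 log units; within the scatter), concerns the chain on the core and lies within the scatter, so it offers no guide to exchanging a vinyl for a hydroxymethyl. Among the compounds with values here, with no measured step bearing on this change, compound 4 is expected to stay near compound 3, estimated at 8000 nM with a range from 3000 nM to 25000 nM. The expected step of a 1.3-fold higher number from compound 3 to compound 4 (0.12 log units; within the scatter) is therefore small and uncertain in direction.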

Compound 4, inhibition constant: 112000 nM
Compound 4: the middle estimate sits 14-fold (1.15 log units) below what was measured, and the stated range ends below it.
By their numbers in this assay, from the lowest: compounds 2 and 1 (each within the scatter of the next); then compound 3; then compound 4.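

In this assay, exchanging vinyl for hydroxymethyl on a saturated chain carbon, two bonds along the chain from an aromatic nitrogen, gives a 19-fold higher number from compound 3 to compound 4 (1.27 log units; beyond the scatter), so the number responds strongly to what ends this chain. The earlier compounds shown here held no comparable step at this place. Nothing available accounts for the size of this step.

On these data alone, whether an amine or a carboxylic acid at the chain end would act like hydroxymethyl remains open. So does whether a longer chain ending in hydroxyl would give a similar number.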